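The source may hold more compounds than are shown below. What is called first, only, known or untested is meant among the compounds shown, and "the series" means these compounds.

Measured compounds in this set:
- compound 1, `COc1ccc(/C=C/C(=O)Nc2cc3c(Nc4ccc(F)c(Cl)c4)ncnc3cc2OC)c(OC)c1`, 38500 nM
- compound 2, `COc1cc(/C=C/C(=O)Nc2cc3c(Nc4ccc(F)c(Cl)c4)ncnc3cc2O[C@H]2CCOC2)cc(OC)c1O`, 26500 nM
- compound 3, `COc1cc(/C=C/C(=O)Nc2cc3c(Nc4ccc(F)c(Cl)c4)ncnc3cc2OC)cc(OC)c1`, "not active" (no number reported), without a number

Working notes. In a functional assay on PC-3 cells (Homo sapiens) for cytotoxicity, read by MTT assay, with a stated time of 72 h (on this read-out higher numbers stand for weaker inhibition and lower numbers for stronger inhibition), compound 2 gives 26500 nM. Its number is the lower of the two reported, but compound 1 at 38500 nM lies within the scatter of it, so no order between compound 2 and compound 1 can be claimed. Compound 3 returned no number in this assay at all; for compound 3 the result is given only as "not active" (no number reported).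

Compound 4, `COc1ccc(/C=C/C(=O)Nc2cc3c(Nc4ccc(F)c(Cl)c4)ncnc3cc2O[C@H]2CCOC2)c(OC)c1OC`, has not been measured in this assay. It differs from compound 2 in one place: 2,3,4-trimethoxyphenyl in place of 4-hydroxy-3,5-dimethoxyphenyl on a double-bonded chain carbon bound to a double-bonded chain carbon. Among the compounds with values here, no step between two measured compounds is available for this change. All three measured compounds differ only in the substitution pattern on this phenyl ring and the core ether, and every number that was obtained sits in the same weak region; one of them gave no number at all. For compound 4 no shift beyond the scatter is expected from compound 2, as the step of a 1.2-fold higher number from compound 2 to compound 4 (0.08 log units; within the scatter) in this assay reflects. Compound 4 is thus estimated at 32000 nM in this assay, within 11000 nM to 95000 nM, with a real chance that only a limit is reported, as for compound 3.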

Compound 4, half-maximal inhibitory concentration: 7670 nM
Compound 4: middle estimate off by 4.2-fold (0.62 log units), on the high side; measured number outside the range, below it.
By their numbers in this assay, from the lowest: compound 4; then compounds 2 and 1 (each within the scatter of the next).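

In this assay the phenyl group on a double-bonded chain carbon bound to a double-bonded chain carbon now shows a step beyond the scatter: a 3.5-fold lower number from compound 2 to compound 4 (0.54 log units; beyond the scatter) with 2,3,4-trimethoxyphenyl in place of 4-hydroxy-3,5-dimethoxyphenyl. The step is modest, but it shows that the read-out responds to a change at this place with the core ether held constant. The change removes the hydrogen-bond donor, adds one heavy atom and rearranges the ring substituents, and no measured data available here account for the lower number.

On these data alone, whether the step goes with the loss of the hydroxy group or with the arrangement of the methoxy groups stays open on this single pair. As far as these compounds go, how an amine or a carboxylic acid on this phenyl ring would read in this assay also remains open.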